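The source may report more compounds than this note shows. Statements on the series, on what has been measured and on what is new or still open speak of the compounds shown alone.

In a functional assay on T47D cells (Homo sapiens) for antiproliferative activity (a lower number here means a stronger inhibitor, a higher number a weaker inhibitor), compound 1 (`CC(C)(C)OC(=O)NCC(CCCCNC(=O)COC1=CC(=O)c2c(O)cccc2C1=O)NC(=O)OC(C)(C)C`) gives 1100 nM, compound 2 (`CC(C)(C)OC(=O)N1CCN(C(=O)COC2=CC(=O)c3c(O)cccc3C2=O)CC1`) gives 800 nM, and compound 3 (`O=C(CCCCC1SCC2NC(=O)NC21)NCCCCCCNC(=O)COC1=CC(=O)c2ccccc2C1=O`) gives 1800 nM. Compound 1 therefore stands within the scatter of both other compounds, and no ranking against either can be drawn. Compound 4 (`CC(C)(C)OC(=O)NCCCCCCNC(=O)COC1=CC(=O)c2c(O)cccc2C1=O`) has not yet been measured. Its difference from compound 1 is hydrogen in place of (tert-butoxycarbonyl)amino on a saturated chain carbon bound to two saturated chain carbons, with the change on a saturated chain carbon bound to two saturated chain carbons. Among the measured compounds shown here, no measured pair isolates this change, so the expectation rests on the narrow set of values alone, and no step beyond the scatter is expected in this assay. The expected step is a 1.1-fold lower number from compound 1 to compound 4 (0.04 log units; within the scatter). The estimated value for compound 4 is 1000 nM, with an expected range of 450 nM to 2200 nM.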

Compound 4, half-maximal inhibitory concentration: 300 nM
For compound 4 the middle estimate is 3.3-fold (0.52 log units) above the measured one; the measured number lies below the stated range.
By their numbers in this assay, from the lowest: compound 4; then compounds 2, 1 and 3 (each within the scatter of the next, the first and the last beyond it).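

In this assay, among the compounds shown here, hydrogen in place of (tert-butoxycarbonyl)amino on a saturated chain carbon bound to two saturated chain carbons gives a 3.7-fold lower number from compound 1 to compound 4 (0.56 log units; beyond the scatter) and this is the only step that can be read. This position therefore responds to substitution, and the (tert-butoxycarbonyl)amino group is not required for activity. Nothing at hand accounts for the step.

From the compounds shown here alone, whether any group on this carbon raises the number remains open. A free amine or a methyl group there would show whether the step depends on the size of the group or on its carbamate.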